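A few compounds are considered here, and "the series" means these few. Any claim that something is new, unique, unknown or untested is made for them only; others in the source may bear on it.

Values in a physicochemical assay for solubility; on this read-out lower numbers stand for lower solubility and higher numbers for higher solubility:
- Compound 1 `CNC(=O)c1cc(C(=O)NC2CCOCC2)n([C@@H](C)c2ccccc2)n1`: 31 ug/mL
- Compound 2 `CNC(=O)c1cc(C(=O)NC)n([C@@H](C)c2ccccc2)n1`: >= 88 ug/mL

In this assay, compound 2 gives only a limit, >= 88 ug/mL, not an exact number. The next molecule, compound 3 `CNC(=O)c1cc(C(=O)N[C@H]2[C@@H]3C[C@@H](O)C[C@@H]32)n([C@@H](C)c2ccccc2)n1`, has not yet been measured. It keeps the shared core, but a methyl on an amide-type nitrogen of compound 2 gives way to a much bigger group carrying a three-membered and a five-membered ring: a group of 7 heavy atoms (6 carbon, 1 oxygen; one three-membered non-aromatic ring of carbon only, one five-membered non-aromatic ring of carbon only) in place of one carbon atom, on an amide-type nitrogen.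

Going by the values given here, one measured step bears on this change. In an at least 2.8-fold higher number from compound 1 to compound 2 (0.45 log units; beyond the scatter), methyl takes the place of oxan-4-yl on an amide-type nitrogen, and the step lies beyond the scatter. Going to compound 3 runs the opposite way, from methyl to a ring-bearing group, so a lower number is expected. On these data alone, the ring-bearing groups of compound 1 and compound 3 are not the same, and this single step has a limit at one end, so its true size is unknown and the expectation stays loose. The expected step is an at least 1.7-fold lower number from compound 2 to compound 3 (0.24 log units; that floor lies within the scatter). Compound 3 is estimated at 50 ug/mL, with an expected range of 20 ug/mL to 120 ug/mL.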

Compound 3, solubility: >= 291 ug/mL
Compound 3: a limit, no number; the forecaster's own chance of this, stated with the estimate: 25%; at least 5.8-fold (0.76 log units) between middle value and limit.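

In this assay compound 3 gives >= 291 ug/mL, which is a limit of the assay and not a number. Replacing oxan-4-yl with the new group gives an at least 9.3-fold higher number from compound 1 to compound 3 (0.97 log units; beyond the scatter), so this position on the amide-type nitrogen can tell two ring-bearing groups of similar size apart. A large group carrying rings here therefore does not by itself bring the number down to that of compound 1, which the step from compound 1 to compound 2 alone could not show. The step from compound 2 to compound 3 cannot be read, as both values are limits, so the small methyl and the larger group cannot be put in order.

The compounds shown leave open how high the true values of compound 2 and compound 3 lie in this assay. They also leave open whether the oxygen or the carbon ring framework of the new group accounts for its difference from oxan-4-yl, a question that a plain cyclopentyl group, with carbon only, on the same nitrogen could begin to separate.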